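The source may hold more compounds than are shown below. What is called first, only, known or untested is meant among the compounds shown, and "the series" means these compounds.

The measured compounds in a functional assay on PC-3 cells (Homo sapiens) for cytotoxicity, read by MTT assay, with a stated time of 72 h (on this read-out lower numbers stand for stronger inhibition and higher numbers for weaker inhibition), are these.
Compound 1 `O=[N+]([O-])c1cccc(COCNc2n[n+]([O-])c3ccccc3[n+]2[O-])c1` gives only a limit of the assay, > 100000 nM.
Compound 2 `[O-][n+]1nc(NCOCc2ccccc2)[n+]([O-])c2ccccc21` gives 11900 nM.
Compound 3 `CC(OCNc1n[n+]([O-])c2ccccc2[n+]1[O-])c1ccccc1` gives 10700 nM.

Compound 2 stands highest of the two numbers; its nearest neighbour is compound 3, and the step from compound 2 to compound 3 is small, a 1.1-fold lower number from compound 2 to compound 3 (0.05 log units; within the scatter). Compound 1 sits at a limit, (the limit of > 100000 nM in this assay, at which 1 of the 3 values shown sits), so the step of an at least 8.4-fold lower number from compound 1 to compound 2 (0.92 log units; beyond the scatter) is known only as a bound on its size.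

Compound 4 `CCCOCNc1n[n+]([O-])c2ccccc2[n+]1[O-]` differs from compound 2 in one place: ethyl in place of phenyl on a saturated chain carbon bound to an oxygen on a saturated carbon. Among the measured compounds shown here, no measured step removes an aromatic ring at this position. The step between compound 2 and compound 3 shows that a methyl added on the saturated chain carbon left the number unchanged within the scatter, while the step from compound 1 to compound 2 concerns a nitro group on an aromatic carbon. The change in compound 4 removes more than either, and a modest rise in the number is expected. Compound 4 is therefore expected to give 25000 nM, within 8000 nM to 100000 nM. The expected step is a 2.1-fold higher number from compound 2 to compound 4 (0.32 log units; beyond the scatter).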

Compound 4, half-maximal inhibitory concentration: 7400 nM
Compound 4: the middle estimate sits 3.4-fold (0.53 log units) above what was measured; the whole stated range lies above it.
By their numbers in this assay, from the lowest: compounds 4, 3 and 2 (each within the scatter of the next). At a limit, above all of these: compound 1.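

Of the steps shown, only this one takes the aromatic ring away at this position, and in this assay it comes out as a 1.6-fold lower number from compound 2 to compound 4 (0.21 log units; within the scatter), so the two numbers cannot be told apart. On this saturated chain carbon bound to an oxygen on a saturated carbon, then, a phenyl is not needed for a number of this size, and an ethyl serves equally well. No measurement shown gives a reason for this.

From the compounds shown here alone, what remains open is whether a longer chain, a branched chain, an amine or a carboxylic acid in place of the ethyl would stay within the scatter of compound 4. Also open, going by these compounds, is whether a nitro group is the only substituent on the phenyl that moves the number as far as in compound 1, whose value is a limit.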